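Bromo for nitro on the aryl group of the aldehyde series

This account rests on a few compounds, and the source may have more. Where it says the series, first, only, none or still open, it means among the compounds named here.

Measured so far:
compound 1, `N#CSc1c(-c2ccccc2)nc2sc(Cc3ccccc3)nn12`, 40700 nM
compound 2, `O=Cc1c(-c2ccc([N+](=O)[O-])cc2)nc2sc(Cc3ccccc3)nn12`, 50100 nM

Two compounds of this series have been run in a functional assay on cells (Cancer cell lines, Homo sapiens) for inhibition; on this read-out higher numbers stand for weaker inhibition of growth and lower numbers for stronger inhibition of growth. Compound 1 gives 40700 nM and compound 2 gives 50100 nM. The two values lie within the scatter of each other, so compound 2 cannot be separated from compound 1 on the concentration for total growth inhibition; both sit in a weak region of the read-out. Compound 1 and compound 2 differ in more than one place, so no single step can be read from them.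

The next compound, compound 3, `O=Cc1c(-c2ccc(Br)cc2)nc2sc(Cc3ccccc3)nn12`, differs from compound 2 in one place: bromo in place of nitro on an aromatic carbon. For the measured compounds named here, no step of this kind has been measured, so there is nothing to anchor a direction. With both measured compounds weak and within scatter of each other, the step from compound 2 to compound 3 is expected to stay within the scatter, a 1.1-fold lower number from compound 2 to compound 3 (0.05 log units; within the scatter). Compound 3 is therefore estimated at 45000 nM in this assay, with a range from 15000 nM to 140000 nM.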

Compound 3, concentration for total growth inhibition: 24600 nM
For compound 3 the middle estimate is 1.8-fold (0.26 log units) above the measured one; measured number inside the range.
By their numbers in this assay, from the lowest: compounds 3, 1 and 2 (each within the scatter of the next, the first and the last beyond it).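

In this assay, for the compounds shown here, bromo in place of nitro on the aromatic carbon para to a large group gives a 2.0-fold lower number from compound 2 to compound 3 (0.31 log units; beyond the scatter), the first single-place step and one beyond the scatter, so this position is not silent on this read-out. The step is modest and gives a direction for this one pair only: nitro, with its hydrogen-bond acceptors, leaves, bromo, with none, enters, and compound 3 at 24600 nM still stands in a weak region of the read-out. No measured evidence ties this step to any property of either group.

As far as these compounds go, whether an amine, a methoxy group or a carboxylic acid on the same aromatic carbon would continue the move toward lower numbers or reverse it remains open. Compound 1 differs from compound 2 in more than one place, so the contribution of the aldehyde cannot be read from the compounds shown, and neither can the effect of leaving this aromatic ring without a substituent in the aldehyde series.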